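Cyano in Place of Trifluoromethyl on the Aryl Ether

This account rests on a few compounds, and the source may have more. Where it says the series, first, only, none or still open, it means among the compounds named here.

Compound 1, `CCN(Cc1cccs1)C(=O)COc1ccc(C(F)(F)F)cc1`: 236 nM
Compound 2, `CCN(Cc1cccs1)C(=O)C(C)Oc1ccc(C)cc1`: 889 nM
Compound 3, `Cc1ccc(OCC(=O)N(Cc2cccs2)c2nccn2C)cc1`: 1790 nM

All three compounds were tested in an assay on HEK293 cells for agonist activity at transient receptor potential cation channel subfamily M member 8 (Homo sapiens), read by fluorescence and calcium flux, with a stated time of 15 min; a higher number here means that more compound is needed for the effect, a lower number that less compound is needed. Among them compound 1 gives the lowest number, so it needs the least compound for the effect. Compound 2 stands above it by a margin beyond the scatter, and compound 3 stands further above still, also beyond the scatter. Compounds 2 and 3 differ from compound 1 in several places at once, so none of these gaps can be pinned on a single change.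

The next compound to be tested is compound 4, `CCN(Cc1cccs1)C(=O)COc1ccc(C#N)cc1`. It differs from compound 1 in one place only: cyano in place of trifluoromethyl on an aromatic carbon. Among the compounds with values here, no pair among the measured compounds shares this exact change, so there is no measured step to lean on; the expectation rests on compound 1 alone and on the size of change involved. A small shift in the direction of a higher number seems the most likely outcome, possibly within the scatter or only just beyond it. The step from compound 1 to compound 4 is expected to be a 2.1-fold higher number from compound 1 to compound 4 (0.33 log units; beyond the scatter). Compound 4 is estimated at 500 nM, with a likely range from 150 nM to 1700 nM.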

Compound 4, half-maximal effective concentration: 1990 nM
Compound 4: middle estimate off by 4.0-fold (0.60 log units), on the low side, outside the stated range (above it).
By their numbers in this assay, from the lowest: compound 1; then compounds 2, 3 and 4 (each within the scatter of the next, the first and the last beyond it).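

In this assay, exchanging trifluoromethyl for cyano on an aromatic carbon, para to a large group, gives an 8.4-fold higher number from compound 1 to compound 4 (0.93 log units; beyond the scatter). Everything else in the core of compound 1 stays the same, so this gap, unlike those involving the earlier compounds, can be assigned to one change, and it shows that the group at this position can shift the amount of compound needed by a margin beyond the scatter. No measurement shown here bears on what lies behind the step, so the result records its size and direction but gives no explanation.

Within the data shown here, with only two groups compared directly at this position, it remains open whether trifluoromethyl is unusually favourable, cyano is unusually unfavourable, or both hold, and a single chlorine atom, a methoxy group or an amine in the same place would help to separate these possibilities. Compounds 2 and 3 carry a methyl group on that ring but also differ from compound 1 elsewhere, so the effect of methyl alone at this position cannot be read from them.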